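A few compounds are considered here, and "the series" means these few. Any claim that something is new, unique, unknown or untested is made for them only; others in the source may bear on it.

The study measured three compounds in a physicochemical assay for lipophilicity; a higher number here means a more lipophilic compound, a lower number a more polar compound. Compound 1 `Cc1c(N(C)C)c(=O)n(C)c(=O)n1C` gave 0.99 in this assay, compound 3 `C=CCn1c(=O)c(N(C)C)c(C)n(-c2ccccc2)c1=O` gave 1.98, and compound 2 `CSc1cccc(-c2nc(N)nc(N)n2)c1` gave 2.16. Compound 2 stands highest of the three numbers. Its nearest neighbour is compound 3, whose number lies lower by an amount within the usual scatter, so these two cannot be placed in order. Compound 1 lies furthest away, with a gap beyond the scatter. Among the compounds with values here, no two of the measured compounds differ from each other in only one place, so no single-change step between measured values is available.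

Compound 4 `Nc1nc(N)nc(-c2cccc(Cl)c2)n1` has not yet been measured in this assay. It differs from compound 2 in one place: chloro in place of methylsulfanyl on an aromatic carbon. Compound 2 is the only measured point from which to reason, and the change simply trades the methylsulfanyl for a chloro at the same aromatic carbon. The step expected in this assay is small, not larger than the scatter, leaning if anything slightly upward: a number 0.09 log units higher from compound 2 to compound 4 (within the scatter). Compound 4 is therefore estimated at 2.25, with a range from 1.85 to 2.65.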

Compound 4, partition coefficient: 2.33
Compound 4: middle estimate off by 0.08 log units, on the low side; the range from low to high includes it.
By their numbers in this assay, from the lowest: compound 1; then compounds 3, 2 and 4 (each within the scatter of the next, the first and the last beyond it).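

With compound 4, the study gains its first single-change step in this assay: putting chloro in place of methylsulfanyl on an aromatic carbon of a six-membered aromatic ring of carbon only gives a number 0.17 log units higher from compound 2 to compound 4 (within the scatter), so the two compounds cannot be placed in order. At this position, then, a chloro of one heavy atom and no hydrogen-bond acceptor stands in for a methylsulfanyl of two heavy atoms and one hydrogen-bond acceptor, and the difference between the two numbers cannot be told apart from the usual scatter of repeated measurements. Nothing in the data shown accounts for how closely the two compounds agree.

The compounds shown cover only this one exchange at this one aromatic carbon, so it remains open whether a group such as an amine, a carboxylic acid or a longer chain there would move the number beyond the scatter. Also open, as far as these compounds go, is whether the exchange of methylsulfanyl for chloro would give a similar step on another aromatic carbon of the ring or on a different core.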